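This account rests on a few compounds, and the source may have more. Where it says the series, first, only, none or still open, it means among the compounds named here.

The study compares two measured compounds and asks what a third would do. Compound 1 `COc1cc(-c2cc(/C=C/C(=O)c3ccc(N)cc3)[nH]n2)cc(OC)c1OC` in a functional assay on PC-3 cells (Homo sapiens) for inhibition, read by sulforhodamine B assay, with a stated time of 48 h (on this read-out lower numbers stand for higher toxicity in this test and higher numbers for lower toxicity in this test), is reported only as a limit of the test, > 100000 nM, not as a number. Compound 2 `COc1ccc(-c2cc(/C=C/C(=O)c3cc(OC)c(OC)c(OC)c3)[nH]n2)cc1OC` gives 48200 nM in this assay. Going by the values given here, no pair of measured compounds here differs in a single place, so no measured step is available. Compound 3 `COc1ccc(C(=O)/C=C/c2cc(-c3cc(OC)c(OC)c(OC)c3)n[nH]2)cc1OC` has not yet been tested in this assay. It differs from compound 1 in one place: 3,4-dimethoxyphenyl in place of 4-aminophenyl on a carbonyl carbon. Because compound 1 sits at the limit (the limit of > 100000 nM in this assay, at which 1 of the 2 values shown sits), any move can only be toward a lower number or none beyond the scatter. A modest move toward lower numbers is expected, an at least 1.4-fold lower number from compound 1 to compound 3 (0.15 log units; that floor lies within the scatter). For compound 3 the expected value in this assay is 70000 nM, with a likely range from 25000 nM to 200000 nM.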

Compound 3, concentration lethal to 50% of the cells: 5760 nM
The estimate for compound 3 lay 12-fold (1.08 log units) above the measured number, and the stated range ends above it.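

In this assay, placing 3,4-dimethoxyphenyl on the carbonyl carbon instead of 4-aminophenyl gives an at least 17-fold lower number from compound 1 to compound 3 (1.23 log units; beyond the scatter). Going by these compounds alone, this is the first measured step, and it shows that the group at this one place can strongly change toxicity in this test while the rest of the molecule stays the same. The value for compound 1 is a limit and not a number, so the true step could be larger than the printed floor: the limit of > 100000 nM in this assay, at which 1 of the 3 values shown sits.

The change removes the amino group and adds two methoxy groups in one move, so the compounds shown cannot tell whether the loss, the gain or both lie behind the step. A plain phenyl group on the same carbonyl carbon would help separate these possibilities.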